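A few compounds are considered here, and "the series" means these few. Any claim that something is new, unique, unknown or untested is made for them only; others in the source may bear on it.

Among the compounds with values here, compound 2 `Cc1nc2c(OCc3ccccc3)cccn2c1C(N)=O` gives 42% in a functional assay on the whole organism with Rattus norvegicus as the target, with a stated time of 4 h, at a dose of 40 mg/kg by the intraperitoneal route (on this read-out higher numbers stand for more inhibition at the one dose given (going by the name of the read-out) and lower numbers for less inhibition), the lower of the two numbers measured so far, while compound 1 `Cc1cn2cccc(OCc3ccccc3)c2n1` gives 62%. Within the data shown here, the only measured step, a number 20 percentage points lower from compound 1 to compound 2 (beyond the scatter), came with a carbamoyl in place of hydrogen on an aromatic carbon. Compound 3 `CC(=O)c1c(C)nc2c(OCc3ccccc3)cccn12` differs from compound 2 by methyl in place of amino on a carbonyl carbon. Among the measured compounds shown here, no measured step trades amino for methyl on a carbonyl carbon, so the step from compound 1 to compound 2 is only a loose guide. The expected step of a number 3 percentage points higher from compound 2 to compound 3 (within the scatter) is therefore none beyond the scatter. Compound 3 is estimated at 45%, between 25% and 65%.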

Compound 3, a percentage reported as inhibition, in the whole organism at one dose (the size of the read-out at that dose, not a potency): 57%
Compound 3: the middle estimate sits 12 percentage points below what was measured, and the stated range covers the measured number.
By their numbers in this assay, from the lowest: compound 2; then compounds 3 and 1 (each within the scatter of the next).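

Within this assay, the group on the carbonyl carbon matters: methyl in place of amino gives a number 15 percentage points higher from compound 2 to compound 3 (beyond the scatter). Acetyl in place of hydrogen on the aromatic carbon gives a number 5 percentage points lower from compound 1 to compound 3 (within the scatter), so, unlike carbamoyl, this group on that carbon brings no change beyond the scatter. Nothing available explains why these two groups differ.

Still open, from the compounds shown here alone, is how a carboxylic acid or a longer chain, such as propanoyl, would fare at this place. Going by these compounds, whether any of these readings would hold at other doses also remains unknown.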